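Replacing 2-nitrophenyl with 4-methoxyphenyl on compound 2

The source may hold more compounds than are shown below. What is called first, only, known or untested is meant among the compounds shown, and "the series" means these compounds.

In a functional assay on CCRF-CEM cells (Homo sapiens) for cytotoxicity (on this read-out lower numbers stand for higher toxicity in this test and higher numbers for lower toxicity in this test), compound 1 (`O=C1Nc2ccccc2/C1=N\c1nc(NC2CC2)c2ncn(C3C=CC(CO)C3)c2n1`) gives 48000 nM and compound 3 (`O=C1Nc2ccc(F)cc2/C1=N\c1nc(NC2CC2)c2ncn(C3C=CC(CO)C3)c2n1`) gives 56000 nM as its reading. Going by the values given here, the fluoro exchange that links them (a 1.2-fold higher number from compound 1 to compound 3 (0.07 log units; within the scatter)) is the only measured step in a single place. Compound 2 (`O=[N+]([O-])c1ccccc1/C=N/c1nc(NC2CC2)c2ncn(C3C=CC(CO)C3)c2n1`) gives 13000 nM as the lowest of the three numbers.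

Compound 4 (`COc1ccc(/C=N/c2nc(NC3CC3)c3ncn(C4C=CC(CO)C4)c3n2)cc1`) has not yet been measured. It carries 4-methoxyphenyl in place of 2-nitrophenyl on a carbon with a double bond to nitrogen. Among the compounds with values here, the fluoro step does not involve this exchange, so it offers only weak guidance, and no measured step tests either group directly. With compound 2 at the low end of the three numbers, a small move toward higher numbers seems the likeliest outcome in this assay, though the direction is uncertain. The expected change is modest (a 1.5-fold higher number from compound 2 to compound 4 (0.19 log units; within the scatter)) and remains an estimate. For compound 4 the estimated value is 20000 nM with an expected range from 7000 nM to 60000 nM on this read-out.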

Compound 4, half-maximal cytotoxic concentration: > 100000 nM
Compound 4: only a limit was reported; the forecaster's own chance of this, stated with the estimate: 10%; middle value at least 5.0-fold (0.69 log units) from the limit.
By their numbers in this assay, from the lowest: compound 2; then compounds 1 and 3 (each within the scatter of the next). At a limit, above all of these: compound 4.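

Going by these compounds alone, the exchange of 2-nitrophenyl for 4-methoxyphenyl on a carbon with a double bond to nitrogen is the first measured change at this position, and in this assay it gives an at least 7.6-fold higher number from compound 2 to compound 4 (0.88 log units; beyond the scatter). Within the data shown here, the group carried here can therefore move the reading beyond the scatter, whereas the only earlier single-place step, made elsewhere on the molecule, was a 1.2-fold higher number from compound 1 to compound 3 (0.07 log units; within the scatter). The reading of compound 4 is a limit of the assay and not a number, and the full size of the step remains unknown: the limit of > 100000 nM in this assay, at which 1 of the 4 values shown sits.

From the compounds shown here alone, whether the step follows from losing the nitro group or from gaining the methoxy group stays open, as both exchanges come together in this one step. Going by these compounds, how a plain phenyl, or a phenyl carrying an amine or a carboxylic acid, would read at this carbon is also open.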